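A Methoxy Becomes a Hydroxy on the Shared Core

The compounds below may be only part of what the source reports. "The series", "measured", "known", "first", "only" and "open" are said of these compounds alone.

Compound 1 `COc1ccc(S(=O)(=O)Nc2ccc(-c3nc4ccccc4o3)cc2)cc1` was tested in an assay on isolated protein for inhibition of malate dehydrogenase, mitochondrial (Sus scrofa), with stated times of 45 min and 30 min; on this read-out lower numbers stand for stronger inhibition and higher numbers for weaker inhibition. In this assay compound 1 reaches only the limit of the measurement, > 63000 nM. Compound 2 `CS(=O)(=O)Nc1ccc2oc(-c3ccccc3)nc2c1` gives > 63000 nM in this assay, a limit rather than a number. Compound 3 `O=S(=O)(Nc1ccc2oc(-c3ccccc3)nc2c1)c1cccc(F)c1` gives > 63000 nM in this assay, also a limit. Among the measured compounds shown here, the one change between compounds differing in a single place, 3-fluorophenyl in place of methyl on a sulfonyl sulfur, yields a step that the two limits leave unreadable from compound 2 to compound 3. All three measured values stand at the limit of > 63000 nM in this assay, at which 3 of the 3 values shown sit.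

Compound 4 `O=S(=O)(Nc1ccc(-c2nc3ccccc3o2)cc1)c1ccc(O)cc1` differs from compound 1 by hydrogen in place of methyl on an oxygen on an aromatic ring; read one bond further out, the methoxy becomes a hydroxy and the 4-methoxyphenyl a 4-hydroxyphenyl. For the measured compounds named here, no measured step touches an oxygen on an aromatic ring, and the only measured step is unreadable, so no direction can be drawn from the series. Everything measured sits at the limit, and compound 4 is therefore expected to stay there too, with a step that the limit leaves unreadable from compound 1 to compound 4 expected to lie within the scatter. Compound 4 is expected to give 80000 nM in this assay, between 20000 nM and 300000 nM.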

Compound 4, half-maximal inhibitory concentration: > 63000 nM
Compound 4: no number, only a limit; the forecaster's own chance of this, stated with the estimate: 75%; the middle value does not contradict the limit.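

Compound 4, like compound 1, ends at a limit rather than a number in this assay, so no step can be read between them. The compounds shown leave open whether any change to these structures would yield a measurable inhibition at all: the limit of > 63000 nM in this assay, at which 4 of the 4 values shown sit.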